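This account rests on a few compounds, and the source may have more. Where it says the series, first, only, none or still open, it means among the compounds named here.

Measured so far in a functional assay on MCF7 cells (Homo sapiens) for antiproliferative activity; on this read-out lower numbers stand for stronger inhibition and higher numbers for weaker inhibition:
Compound 1 `CC(C)=CCc1cc(C(=O)Nc2cc3ccc(OCCCN4CCCCC4)c(C)c3oc2=O)ccc1O`: > 50000 nM, a limit of the assay.
Compound 2 `CC(C)=CCc1cc(C(=O)Nc2cc3ccc(OCCCNC(C)(C)C)c(C)c3oc2=O)ccc1O`: 950 nM.

Going by the values given here, compound 2 holds the only true number in this short series, at 950 nM. The entry for compound 1 is a limit and not a number.

The next compound, compound 3 `CC(C)=CCc1cc(C(=O)Nc2cc3ccc(OCCCNCC(N)=O)c(C)c3oc2=O)ccc1O`, keeps the shared core and the chain and differs from compound 2 only at the far end: carbamoylmethyl in place of tert-butyl on an amine nitrogen.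

Among the compounds with values here, one measured step bears on this change, an at least 52-fold lower number from compound 1 to compound 2 (1.72 log units; beyond the scatter). It is large and falls at the same end of the chain, so substitution there can move this assay a long way. It involves a different pair of groups, however, and gives no direct reading for carbamoylmethyl. With compound 2 as the only measured reference, at 950 nM, a clear move towards weaker inhibition seems more likely than none, though smaller than that large step.

The expected move is a 4.2-fold higher number from compound 2 to compound 3 (0.62 log units; beyond the scatter). For compound 3 the estimated value is 4000 nM, with an expected range from 1000 nM to 25000 nM.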

Compound 3, half-maximal inhibitory concentration: 1460 nM
Estimate against measurement, compound 3: 2.7-fold (0.44 log units) above; measured number inside the range.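

In this assay, carbamoylmethyl in place of tert-butyl on the amine nitrogen gives a 1.5-fold higher number from compound 2 to compound 3 (0.19 log units; within the scatter), so this position tolerates the exchange of an all-carbon group for one that brings a hydrogen-bond donor and a hydrogen-bond acceptor, with no change that stands out from the scatter. (Carbamoylmethyl)amino in place of piperidin-1-yl gives an at least 34-fold lower number from compound 1 to compound 3 (1.53 log units; beyond the scatter), which shows that the large difference seen earlier with (tert-butyl)amino is not particular to tert-butyl. The entry for compound 1 is a limit and not a number, so the true size of both steps that start from it stays undefined: the limit of > 50000 nM in this assay, at which 1 of the 3 values shown sits.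

The compounds shown leave open whether the piperidin-1-yl ring itself goes with the loss of activity, or whether any fully substituted amine does; a dimethylamino group or a morpholin-4-yl ring at the end of the chain would help separate these two readings. They also leave open how far the far end of the chain can vary, for instance with a carboxylic acid in place of the primary amide of carbamoylmethyl, or with a longer chain carrying the same (carbamoylmethyl)amino group.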